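This account rests on a few compounds, and the source may have more. Where it says the series, first, only, none or still open, it means among the compounds named here.

Compound 1 `CCCCSc1nc(N)c2nc(O)n(Cc3ccccc3)c2n1` stands lowest of the two numbers in hand: in a functional assay (spleen, spleen) for activation, with Mus musculus as the target (on this read-out lower numbers stand for an effect already at smaller amounts and higher numbers for an effect only at larger amounts of compound), compound 1 gives 0.01 uM, while compound 2 `COc1ccccc1Cn1c(O)nc2c(N)ncnc21` gives 10 uM in this assay, a gap far beyond the scatter. Among the compounds with values here, no step between measured compounds separates the two. Compound 3 `Nc1nc(S)nc2c1nc(O)n2Cc1ccccc1` differs from compound 1 by hydrogen in place of butyl on a sulfur. Within the data shown here, with no measured pair to anchor this change, the expectation is only an estimate: compound 3 is expected to move toward higher numbers, by a step of a 100-fold higher number from compound 1 to compound 3 (2.00 log units; beyond the scatter) in this assay, landing near 1 uM with a range of 0.1 uM to 10 uM.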

Compound 3, minimum effective concentration: 10 uM
Compound 3: middle estimate off by 10-fold (1.00 log units), on the low side; the range from low to high includes it.
By their numbers in this assay, from the lowest: compound 1; then compounds 2 and 3 (each within the scatter of the next).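

In this assay, within the data shown here, the change from butylsulfanyl to sulfanyl is the first single-place comparison, and it gives a 1000-fold higher number from compound 1 to compound 3 (3.00 log units; beyond the scatter). The read-out is therefore highly sensitive to this one substituent on the sulfur, with the rest of the core of compound 1 unchanged. The data offer no explanation for the size of this step.

Still open, on these data alone, is how a methyl or a longer chain such as hexyl on the sulfur would read. Also open, as far as these compounds go, is whether an amine in place of the butylsulfanyl group would keep the low number of compound 1.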